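The compounds below may be only part of what the source reports. "The series", "measured", "known", "first", "only" and "open" are said of these compounds alone.

Measured compounds in the series:

Compound 1, `CN1[C@@H]2c3[nH]c4ccccc4c3C[C@H]1[C@H](C#N)N1[C@@H](CN3C(=O)c4ccccc4C3=O)c3[nH]c4ccccc4c3C[C@@H]21`: in a functional assay on A2780 cells (Homo sapiens) for cytotoxicity, read by MTT assay, with a stated time of 72 h (on this read-out lower numbers stand for stronger inhibition and higher numbers for weaker inhibition), compound 1 gives 80 nM.
Compound 2, `COc1ccc(C(=O)NC[C@H]2c3[nH]c4ccccc4c3C[C@H]3[C@H]4c5[nH]c6ccccc6c5C[C@@H]([C@H](C#N)N23)N4C)cc1`: in this assay compound 2 gives 320 nM.
Compound 3, `CCc1ccc(C(=O)NC[C@H]2c3[nH]c4ccccc4c3C[C@H]3[C@H]4c5[nH]c6ccccc6c5C[C@@H]([C@H](C#N)N23)N4C)cc1`: in this assay compound 3 gives 670 nM.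

Compound 2 stands second highest of the three numbers. Its nearest neighbour is compound 3, reached by a 2.1-fold higher number from compound 2 to compound 3 (0.32 log units; beyond the scatter); the furthest is compound 1, from which compound 2 is reached by a 4.0-fold higher number from compound 1 to compound 2 (0.60 log units; beyond the scatter). The three compounds share the same core and differ only in the group attached through the saturated chain carbon bound to a saturated ring carbon.

Compound 4, `CN1[C@@H]2c3[nH]c4ccccc4c3C[C@H]1[C@H](C#N)N1[C@@H](CNC(=O)c3cccc4c3CCCC4)c3[nH]c4ccccc4c3C[C@@H]21`, is not yet measured. It differs from compound 2 in one place: 1,2,3,4-tetrahydronaphthalen-5-yl in place of 4-methoxyphenyl on a carbonyl carbon.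

For the measured compounds named here, only one measured step touches the same position in the same amide series, a 2.1-fold higher number from compound 2 to compound 3 (0.32 log units; beyond the scatter), where a methoxy on the aromatic carbon is exchanged for ethyl and the number rises modestly. Going by the values given here, the step into compound 4 also removes the methoxy and replaces it with a carbon-only saturated ring fused to the aromatic ring, so a change of similar direction and size is expected in this assay, though the data give no step of exactly this kind. For compound 4 the expected number is 550 nM, with a range of 220 nM to 1400 nM. This estimate corresponds to an expected step of a 1.7-fold higher number from compound 2 to compound 4 (0.24 log units; within the scatter).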

Compound 4, half-maximal inhibitory concentration: 810 nM
Compound 4: the middle estimate sits 1.5-fold (0.17 log units) below what was measured, within the range that was stated.
By their numbers in this assay, from the lowest: compound 1; then compound 2; then compounds 3 and 4 (each within the scatter of the next).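

In this assay, putting 1,2,3,4-tetrahydronaphthalen-5-yl in place of 4-methoxyphenyl on the carbonyl carbon gives a 2.5-fold higher number from compound 2 to compound 4 (0.40 log units; beyond the scatter), so a second group of carbon only now stands on the side of the weaker numbers relative to compound 2. The comparison with the ethyl amide gives a 1.2-fold higher number from compound 3 to compound 4 (0.08 log units; within the scatter), so 4-ethylphenyl and 1,2,3,4-tetrahydronaphthalen-5-yl cannot be told apart at this position in this assay, even though the latter brings an extra six-membered non-aromatic ring. This pattern rests on compound 2, compound 3 and compound 4 alone, with no compound among them going against it, and no measurement at hand bears on the reason for it.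

The compounds shown leave open whether 4-hydroxyphenyl, 4-aminophenyl or plain phenyl on the same carbonyl carbon would group with compound 2 or with compound 3 and compound 4. Also open, going by these compounds, is whether a benzyl group on that carbonyl carbon would come any closer to compound 1, which gives 80 nM in this assay.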